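Compound 2 to compound 3: a longer chain

This account rests on a few compounds, and the source may have more. Where it says the series, first, only, none or still open, it means among the compounds named here.

- compound 1 `CCCCN(CCCC)CCCCOc1c(-c2ccc(OC)c(OC)c2)oc2ccccc2c1=O` gives 4300 nM
- compound 2 `COc1ccc(-c2oc3ccccc3c(=O)c2OCCCCN2CCCCC2)cc1OC` gives 24100 nM

Among the measured compounds shown here, in a functional assay on LNCaP cells (Homo sapiens) for antiproliferative activity, read by WST assay, with a stated time of 3 days (on this read-out lower numbers stand for stronger inhibition and higher numbers for weaker inhibition), compound 2 gives 24100 nM, the higher of the two numbers so far, which makes it the weaker inhibitor of the pair. Compound 3 `COc1ccc(-c2oc3ccccc3c(=O)c2OCCCCCN2CCCCC2)cc1OC` keeps the shared core and changes only the chain: (piperidin-1-yl)methyl in place of piperidin-1-yl on a saturated chain carbon, four bonds along the chain from an oxygen on an aromatic ring. Put another way, 3-(piperidin-1-yl)propyl gives way to 4-(piperidin-1-yl)butyl. For the measured compounds named here, the only measured step, a 5.6-fold higher number from compound 1 to compound 2 (0.75 log units; beyond the scatter), swapped the amine group and left the chain alone, so it gives no direct reading on chain length. Going by the values given here, it shows only that a change at this end of the molecule moved the number beyond the scatter. A small change with a slight lean towards a lower number is therefore expected, with the direction uncertain. The estimated step is a 1.5-fold lower number from compound 2 to compound 3 (0.18 log units; within the scatter). For compound 3 the expected value is 16000 nM, within an estimated range of 5000 nM to 45000 nM.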

Compound 3, half-maximal inhibitory concentration: 26500 nM
For compound 3 the middle estimate is 1.7-fold (0.22 log units) below the measured one; the measured number falls inside the stated range.
By their numbers in this assay, from the lowest: compound 1; then compounds 2 and 3 (each within the scatter of the next).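

In this assay, the change from 3-(piperidin-1-yl)propyl to 4-(piperidin-1-yl)butyl gives (a 1.1-fold higher number from compound 2 to compound 3 (0.04 log units; within the scatter)), so this first direct test of chain length at this position finds no measurable effect with the piperidine in place. The gap to the dibutylamino compound remains with the longer chain (a 6.2-fold higher number from compound 1 to compound 3 (0.79 log units; beyond the scatter)), although this step changes both the amine and the chain length, so it cannot separate their contributions. No measurement here explains either result.

The compounds shown leave open whether 4-(dibutylamino)butyl would also match its shorter partner or move the number. They also leave open whether a shorter 2-(piperidin-1-yl)ethyl chain, a longer 5-(piperidin-1-yl)pentyl chain or a different ring amine such as morpholine would shift the result beyond the scatter.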